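This account rests on a few compounds, and the source may have more. Where it says the series, first, only, none or still open, it means among the compounds named here.

In a functional assay on CCRF-CEM/VCR-1000 cells (Homo sapiens) for inhibition (on this read-out higher numbers stand for weaker inhibition and lower numbers for stronger inhibition), three compounds built on a shared aryl ketone with an aryloxy-hydroxypropyl-amine side chain have been measured. Compound 1 `O=C(CCc1ccccc1)c1cccc(OCC(O)CN2CCN(c3ccc(F)cc3)CC2)c1` gives 1120 nM. Compound 2 `CC(=O)c1cccc(OCC(O)CN2CCN(c3ccc(F)cc3)CC2)c1` gives 11400 nM, and compound 3 `CC(=O)c1cccc(OCC(O)CN2CCCCC2)c1` gives 9070 nM; the values of compound 2 and compound 3 lie close to one another, within the usual scatter, so nothing is made of their order here. Compound 2 and compound 1 differ in one place, namely (benzyl in place of hydrogen on a saturated chain carbon bound to a carbonyl carbon), and this change produced a 10-fold lower number from compound 2 to compound 1 (1.01 log units; beyond the scatter). The difference between the core of compound 2 and the core of compound 3 is not broken down here.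

Compound 4 `O=C(CCc1ccccc1)c1cccc(OCC(O)CN2CCCCC2)c1` has not yet been measured. It stands to compound 3 as compound 1 stands to compound 2: the change is benzyl in place of hydrogen on a saturated chain carbon bound to a carbonyl carbon, the same change as before, at the same place. Among the compounds with values here, the expectation for compound 4 is a step of a 10-fold lower number from compound 3 to compound 4 (1.00 log units; beyond the scatter) in this assay, because a 10-fold lower number from compound 2 to compound 1 (1.01 log units; beyond the scatter) is the single measured instance of this change and the only guide. Compound 4 is therefore estimated at 900 nM, between 300 nM and 2700 nM.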

Compound 4, half-maximal inhibitory concentration: 390 nM
Compound 4: the middle estimate sits 2.3-fold (0.36 log units) above what was measured; low and high end bracket the measured number.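

In this assay, benzyl in place of hydrogen on a saturated chain carbon bound to a carbonyl carbon gave a 23-fold lower number from compound 3 to compound 4 (1.37 log units; beyond the scatter) on the core of compound 3, and the step can be set directly beside the one seen earlier on the core of compound 2: the same change on two cores in this assay, a 10-fold lower number (1.01 log units; beyond the scatter) from compound 2 to compound 1 and a 23-fold lower number (1.37 log units; beyond the scatter) from compound 3 to compound 4, 2.3-fold (0.36 log units) apart, within the scatter of two such steps. The change therefore carried from one core to the other, with a large step on both and no difference between them beyond the scatter. Within the data shown here, this rests on only two cores, however, and it neither shows that the step would hold on other cores nor explains why it occurs.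

The compounds shown leave open whether the benzyl group's aromatic ring is needed, which a cyclohexylmethyl group in its place would test. They also leave open how a longer chain, or an amine or a carboxylic acid at the end of the chain, would compare with benzyl.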